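The compounds below may be only part of what the source reports. "The series", "measured", "known", "first", "only" and "open" are said of these compounds alone.

Measured so far in an ADME assay on microsomes from liver (Mus musculus) for metabolic stability, read by LC-MS, using NADPH, with stated times of 15 min and 60 min, tested at 4.6 uM; a higher number here means that the compound lasts longer, a lower number that the compound disappears faster:
compound 1, `O=C(NCCCCc1ccccc1)n1c2c(oc1=O)CNCC2`: < 0.25 h, a limit of the assay
compound 2, `CC(C)CNC(=O)n1c(=O)oc2cc(C3CCCN(C)C3)ccc21`: > 1 h, a limit of the assay
compound 3, `CCN1CCC(c2ccc3c(c2)oc(=O)n3C(=O)NCCCCc2ccccc2)CC1`: 1 h

Compound 3 is the only one of the three with a number rather than a limit in this assay. Compound 1 sits at the limit of < 0.25 h in this assay, at which 1 of the 3 values shown sits. Compound 2 sits at the limit of > 1 h in this assay, at which 1 of the 3 values shown sits. Compound 4, `CN1CCC(c2ccc3c(c2)oc(=O)n3C(=O)NCCCCc2ccccc2)CC1`, has not yet been measured in this assay. It differs from compound 3 by hydrogen in place of methyl on a saturated chain carbon bound to an amine nitrogen in a ring. Going by the values given here, no step between two measured compounds covers this change, so there is nothing to set its size against directly. Compound 2 also carries a 1-methylpiperidin-4-yl group and gives only a limit. For the step from compound 3 to compound 4 no change beyond the scatter is expected in this assay: no change at the digits printed from compound 3 to compound 4 (within the scatter). Compound 4 is therefore estimated at 1 h, within 0.5 h to 2 h, with a fair chance that this assay reports only a limit for it.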

Compound 4, half-life: 0.667 h
Compound 4: the middle estimate sits 1.5-fold (0.18 log units) above what was measured, and the stated range covers the measured number.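

In this assay, going by these compounds alone, hydrogen in place of methyl on a saturated chain carbon bound to an amine nitrogen in a ring gives a 1.5-fold lower number from compound 3 to compound 4 (0.18 log units; within the scatter), the first readable step at this place. Both compounds carry numbers rather than limits, and at this scatter 1-ethylpiperidin-4-yl and 1-methylpiperidin-4-yl cannot be told apart by half-life. No measured property at hand bears on this step.

As far as these compounds go, whether the ring nitrogen tolerates more than this one small change remains open, as a single step says nothing about isopropyl, 2-hydroxyethyl or a free amine hydrogen there. Compound 1 and compound 2 differ from this pair in more than one place, so whether the step carries over to their side chains or cores also stays unresolved.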